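The source may report more compounds than this note shows. Statements on the series, on what has been measured and on what is new or still open speak of the compounds shown alone.

Measured so far:
- compound 1 `Nc1ccc(Nc2c(C(=O)NCc3ccc(F)cc3)nc(Br)c3cccnc23)cc1`: 4000 nM
- compound 2 `CN(C)CCCNc1c(C(=O)NCc2ccc(F)cc2)nc(Br)c2cccnc12`: 7000 nM
- compound 3 `NCCNc1c(C(=O)NCc2ccc(F)cc2)nc(Br)c2cccnc12`: 6000 nM

In a functional assay on MCF7 cells (Homo sapiens) for cytotoxicity, read by MTT assay, with a stated time of 72 h (a lower number here means a stronger inhibitor, a higher number a weaker inhibitor), compound 3 gives 6000 nM, which lies within the scatter of both other compounds: a 1.2-fold lower number from compound 2 to compound 3 (0.07 log units; within the scatter) and a 1.5-fold higher number from compound 1 to compound 3 (0.18 log units; within the scatter).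

Compound 4 `O=C(NCc1ccc(F)cc1)c1nc(Br)c2cccnc2c1N1CCNCC1` has piperazin-1-yl in place of (2-aminoethyl)amino on an aromatic carbon, para to a bromo group: piperazin-1-yl in place of (2-aminoethyl)amino on an aromatic carbon.

The measured swaps of this substituent are all small: a 1.8-fold higher number from compound 1 to compound 2 (0.24 log units; within the scatter), together with the two steps above. Within the data shown here, no measured compound carries a six-membered non-aromatic ring here, so the evidence is indirect. No change beyond the scatter is expected in this assay, and the expected step is no change at the digits printed from compound 3 to compound 4 (within the scatter). The estimated value for compound 4 is 6000 nM, with an expected range from 2500 nM to 15000 nM.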

Compound 4, half-maximal inhibitory concentration: 7000 nM
Compound 4: middle estimate off by 1.2-fold (0.07 log units), on the low side; measured number inside the range.
By their numbers in this assay, from the lowest: compounds 1, 3, 2 and 4 (each within the scatter of the next).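

In this assay, piperazin-1-yl, a six-membered non-aromatic ring with 2 hetero atoms, stays within the scatter of all three earlier amines at this aromatic carbon (a 1.2-fold higher number from compound 3 to compound 4 (0.07 log units; within the scatter); no change at the digits printed from compound 2 to compound 4 (within the scatter); a 1.8-fold higher number from compound 1 to compound 4 (0.24 log units; within the scatter)). Ring and open chain are therefore not separated here, and no substituent step among these four compounds goes beyond the scatter. Nothing at hand explains this flat response.

Open, as far as these compounds go, is whether morpholin-4-yl or a chain ending in a carboxylic acid would give a step beyond the scatter at this position.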